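The compounds below may be only part of what the source reports. "The series", "measured", "known", "first", "only" and "open" are said of these compounds alone.

Of the compounds shown here, three built on the same core have been tested in a functional assay on DU-145 cells (Homo sapiens) for antiproliferative activity, read by sulforhodamine B assay, with a stated time of 72 h; on this read-out higher numbers stand for weaker inhibition of growth and lower numbers for stronger inhibition of growth. Compound 1 `Cc1cc(=O)oc2cc(Sc3cccc(Cl)[n+]3[O-])ccc12` did not give a number: its result is the limit > 31200 nM, which is the limit of > 31200 nM in this assay, at which 1 of the 3 values shown sits. Compound 2 `Cc1cc(=O)oc2cc(Sc3cccc(Cl)n3)ccc12` gives 1150 nM in this assay. Compound 3 `Cc1cc(=O)oc2cc(SCc3ccccn3)ccc12` likewise stops at a limit, > 35200 nM, and so sits at the limit of > 35200 nM in this assay, at which 1 of the 3 values shown sits; of the three values shown, it is one of the two that are limits rather than numbers, so its growth inhibition is known only to be weak.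

Compound 4 `Cc1cc(=O)oc2cc(SCc3cccnc3)ccc12` has the same atoms as compound 3, joined differently: pyridin-3-yl in place of pyridin-2-yl on a saturated chain carbon bound to a sulfur. Going by the values given here, no measured pair among the three compounds shows this kind of change, so nothing here gives its size. Compound 3 already lies at a limit, and the expected step from compound 3 to compound 4 is a number no higher from compound 3 to compound 4 (the limit leaves the size open), that is, none beyond the scatter. The estimate for compound 4 in this assay is therefore 35000 nM, with a range from 12000 nM to 100000 nM, and it is expected that the assay may again report only a limit.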

Compound 4, concentration for 50% growth inhibition: > 35200 nM
Compound 4 was reported as a limit; the forecaster's own chance of this, stated with the estimate: 65%; middle value at least 1.0-fold (0.00 log units) from the limit.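

Compound 3 and compound 4 both stop at a limit, and the step between them cannot be read. The compounds shown leave open whether pyridin-3-yl in place of pyridin-2-yl on a saturated chain carbon bound to a sulfur changes growth inhibition at all.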